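The source may hold more compounds than are shown below. What is called first, only, known or untested is meant among the compounds shown, and "the series" means these compounds.

Compound 3 `c1ccc(-c2cn[nH]c2)c(NCC2=NCCN2)c1` stands highest of the three numbers in a functional assay with Alpha-1B adrenergic receptor (Homo sapiens) as the target, read by calcium flux (on this read-out higher numbers stand for larger maximal responses and lower numbers for smaller maximal responses), where compound 3 gives 72%; compound 1 `Cn1cc(-c2ccccc2NCC2=NCCN2)cn1` gives 0% and compound 2 `CCCn1nccc1-c1ccccc1NCC1=NCCN1` gives 0%. Compound 4 `Cn1nccc1-c1ccccc1NCC1=NCCN1` is not yet measured; it differs from compound 3 by 1-methyl-1H-pyrazol-5-yl in place of 1H-pyrazol-4-yl on an aromatic carbon. Within the data shown here, the one measured step that bears on this is a number 72 percentage points higher from compound 1 to compound 3 (beyond the scatter), which points the opposite way from the present change, since compound 4 again carries methyl on an aromatic nitrogen, as does compound 1 with 0% and compound 2 with 0%. A large downward step is therefore expected, a number 67 percentage points lower from compound 3 to compound 4 (beyond the scatter). The maximal response of compound 4 is estimated at 5%, within a range of 0% to 30%.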

Compound 4, largest response reached (reported as maximal response), in percent of the reference or control that the assay uses: 0%
For compound 4 the middle estimate is 5 percentage points above the measured one, and the stated range covers the measured number.
By their numbers in this assay, from the lowest: compounds 1, 2 and 4 (each within the scatter of the next); then compound 3.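

In this assay, no change at the digits printed from compound 1 to compound 4 (within the scatter) with 1-methyl-1H-pyrazol-5-yl in place of 1-methyl-1H-pyrazol-4-yl, and no change at the digits printed from compound 2 to compound 4 (within the scatter) with the shorter chain on the aromatic nitrogen. With a number 72 percentage points lower from compound 3 to compound 4 (beyond the scatter) as well, the response among these four compounds appears only in compound 3, the one with an unsubstituted pyrazole nitrogen, and no compound shown goes against this. As far as these compounds go, whether 1H-pyrazol-5-yl or 1H-imidazol-4-yl would keep the response remains open. No measured evidence here accounts for the loss of response.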